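The source may hold more compounds than are shown below. What is called first, only, known or untested is meant among the compounds shown, and "the series" means these compounds.

Compound 1 `COc1cc(-c2nn(-c3cccc(NC(=O)c4cccc(C(F)(F)F)c4)c3)cc2-c2ccncc2)ccc1Cl`: 1400 nM
Compound 2 `O=C(Nc1cccc(-n2cc(-c3ccncc3)c(-c3ccc(Cl)c(O)c3)n2)c1)Nc1cc(C(F)(F)F)cc(C(F)(F)F)c1`: 433 nM
Compound 3 `COc1cc(-c2nn(-c3cccc(NC(=O)Nc4cccc(C(F)(F)F)c4)c3)cc2-c2ccncc2)ccc1Cl`: 584 nM

In a functional assay on K562 cells (Homo sapiens) for inhibition, read by sulforhodamine B assay, with a stated time of 48 h (a lower number here means a stronger inhibitor of growth, a higher number a weaker inhibitor of growth), compound 1 stands highest of the three; the nearest number is that of compound 3, the difference being a 2.4-fold lower number from compound 1 to compound 3 (0.38 log units; beyond the scatter), while compound 2 lies further off at 433 nM. Compound 4 `COc1cc(-c2nn(-c3cccc(NC(=O)c4ccccc4)c3)cc2-c2ccncc2)ccc1Cl` differs from compound 1 by hydrogen in place of trifluoromethyl on an aromatic carbon, the change sitting on an aromatic carbon of a six-membered aromatic ring of carbon only, meta to a large group. Among the compounds with values here, no measured step removes a trifluoromethyl; the one measured step concerns the linker, not this group, so the data give no guide to direction. Compound 4 is therefore expected to change little, perhaps weakening slightly, an estimated 1.6-fold higher number from compound 1 to compound 4 (0.20 log units; within the scatter). The estimate for compound 4 is 2200 nM, between 800 nM and 6000 nM.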

Compound 4, concentration for 50% growth inhibition: 421 nM
Compound 4: the middle estimate sits 5.2-fold (0.72 log units) above what was measured; measured number outside the range, below it.
By their numbers in this assay, from the lowest: compounds 4, 2 and 3 (each within the scatter of the next); then compound 1.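

In this assay, hydrogen in place of trifluoromethyl gives a 3.3-fold lower number from compound 1 to compound 4 (0.52 log units; beyond the scatter), so on this aromatic carbon the trifluoromethyl is not needed for growth inhibition in this pair. Phenyl in place of (3-(trifluoromethyl)phenyl)amino on the carbonyl carbon gives a 1.4-fold lower number from compound 3 to compound 4 (0.14 log units; within the scatter), so the plain benzoyl compound matches the linker change seen earlier without any trifluoromethyl. Nothing at hand explains the result. The compounds shown leave open whether fluorine, methyl or an amine on this same carbon would hold this level. They also leave open whether the same removal would act alike in compound 3.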